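Imidazolidinone-piperidine indoles: removing the ring isopropyl

This account rests on a few compounds, and the source may have more. Where it says the series, first, only, none or still open, it means among the compounds named here.

Measured compounds:
compound 1, `CC(C)N1CCN(CCN2CCC(c3cn(-c4ccc(F)cc4)c4cc(C(F)(F)F)ccc34)CC2)C1=O`, 91 nM
compound 2, `O=C1NCCN1CCN1CCC(c2cn(-c3ccc(F)cc3)c3cc(C(F)(F)F)ccc23)CC1`, 33 nM
compound 3, `CC(C)N1CCN(CCN2CCC(c3cn(-c4ccc(F)cc4)c4cc(F)ccc34)CC2)C1=O`, 13 nM

In an assay on cell membranes for displacement of a labelled ligand from Adrenergic receptor alpha-1 (Rattus norvegicus) (on this read-out lower numbers stand for stronger inhibition and higher numbers for weaker inhibition), compound 1 gives 91 nM. Two single changes have been made from it. The change hydrogen in place of isopropyl on an amide-type nitrogen in a ring brings a 2.8-fold lower number from compound 1 to compound 2 (0.44 log units; beyond the scatter). The change fluoro in place of trifluoromethyl on an aromatic carbon brings a 7.0-fold lower number from compound 1 to compound 3 (0.85 log units; beyond the scatter). Compound 3 gives the lowest of the three numbers, and both of its steps to the others lie beyond the scatter.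

Compound 4, `O=C1NCCN1CCN1CCC(c2cn(-c3ccc(F)cc3)c3cc(F)ccc23)CC1`, is not yet measured in this assay. It differs from compound 3 by hydrogen in place of isopropyl on an amide-type nitrogen in a ring. This is the same change that was made from compound 1 to compound 2, at a place described in the same words; the two cores differ by fluoro in place of trifluoromethyl on an aromatic carbon. Among the measured compounds shown here, with only one earlier instance of the change, the expectation for compound 4 rests on that single step: a step of about a 2.6-fold lower number from compound 3 to compound 4 (0.41 log units; beyond the scatter) is expected, because compound 2 showed a 2.8-fold lower number from compound 1 to compound 2 (0.44 log units; beyond the scatter) against compound 1. On that basis compound 4 is expected to give about 5 nM in this assay, with a range from 2 nM to 13 nM.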

Compound 4, half-maximal inhibitory concentration: 2.2 nM
Compound 4: the middle estimate sits 2.3-fold (0.36 log units) above what was measured; the range from low to high includes it.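

In this assay, hydrogen in place of isopropyl on the amide-type nitrogen again lowers the number, with a 5.9-fold lower number from compound 3 to compound 4 (0.77 log units; beyond the scatter), and the two instances of this change cannot be told apart in size: the same change on two cores in this assay, a 2.8-fold lower number (0.44 log units; beyond the scatter) from compound 1 to compound 2 and a 5.9-fold lower number (0.77 log units; beyond the scatter) from compound 3 to compound 4, 2.1-fold (0.33 log units) apart, within the scatter of two such steps. Fluoro in place of trifluoromethyl also carries over, with a 15-fold lower number from compound 2 to compound 4 (1.18 log units; beyond the scatter), and its two instances likewise cannot be told apart in size: the same change on two cores in this assay, a 7.0-fold lower number (0.85 log units; beyond the scatter) from compound 1 to compound 3 and a 15-fold lower number (1.18 log units; beyond the scatter) from compound 2 to compound 4, 2.1-fold (0.33 log units) apart, within the scatter of two such steps. On these two cores, each change therefore acts in the same direction and to a size consistent with its earlier instance, with no sign that one change depends on the other, but two cores do not establish a rule for the series, and the result says nothing about why either change lowers the number.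

Left open is how a methyl or a longer alkyl chain on the amide-type nitrogen would read. Also open, going by these compounds, is how a chloro or a nitrile would read in place of fluoro on the aromatic carbon.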